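This account rests on a few compounds, and the source may have more. Where it says the series, first, only, none or still open, it means among the compounds named here.

Compound 2 `O=S(=O)(Nc1ccc(-c2nc3ccccc3o2)cc1)c1ccccc1O` belongs to a small set of sulfonamides tested in an ADME assay on HEK293 cells (Homo sapiens) for cytotoxicity, read by resazurin assay, with a stated time of 48 h; a lower number here means that less compound is tolerated, a higher number that more compound is tolerated. There compound 2 gives > 100000 nM, which is a limit of the assay rather than a number. Compound 1 `O=S(=O)(Nc1ccc(-c2nc3ccccc3o2)cc1)c1ccccc1C(F)(F)F` in this assay also reaches only a limit, > 100000 nM. Compound 3 `O=S(=O)(Nc1ccc2oc(-c3ccccc3)nc2c1)c1ccc(Cl)c(C(F)(F)F)c1`, built on a differently arranged shared core, gives 66000 nM in this assay. Among the compounds with values here, the one single-point change measured, a step that the two limits leave unreadable from compound 1 to compound 2, cannot be read because both of its values sit at the limit of > 100000 nM in this assay, at which 2 of the 3 values shown sit. Compound 4 `CCc1ccc(S(=O)(=O)Nc2ccc(-c3nc4ccccc4o3)cc2)cc1` differs from compound 2 by 4-ethylphenyl in place of 2-hydroxyphenyl on a sulfonyl sulfur. No readable measured step bears on this change, so no step beyond the scatter is expected. Compound 4 is therefore estimated at 100000 nM, between 40000 nM and 250000 nM, a step of a number no higher from compound 2 to compound 4 (the limit leaves the size open) that is expected to stay within the scatter.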

Compound 4, half-maximal cytotoxic concentration: 82000 nM
For compound 4 the middle estimate is 1.2-fold (0.09 log units) above the measured one; the range from low to high includes it.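

Within the data shown here, compound 4 gives the first readable number for a group on this sulfonyl sulfur of the shared core, so this position no longer rests on limits alone. In this assay the change to 4-ethylphenyl, which has no hydrogen-bond donor, gives an at least 1.2-fold lower number from compound 2 to compound 4 (0.08 log units; that floor lies within the scatter). From the compounds shown here alone, its true size stays open because compound 2 sits at a limit: the limit of > 100000 nM in this assay, at which 2 of the 4 values shown sit.

Going by these compounds, whether an amine on that ring, or a butyl chain in place of the ethyl, would lower the number beyond the scatter remains open.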